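Cyclopentyl on the sulfonamide nitrogen of compound 3

A few compounds are considered here, and "the series" means these few. Any claim that something is new, unique, unknown or untested is made for them only; others in the source may bear on it.

In an ADME assay on microsomes from liver (Mus musculus) for metabolic stability, tested at 5 uM (on this read-out lower numbers stand for a shorter-lived compound and higher numbers for a longer-lived compound), compound 1 (`CCCCCCNc1ccc(C(=O)O)cc1S(=O)(=O)NC`) gives 0.483 h, and compound 2 (`CCCCCCCCNc1ccc(C(=O)O)cc1S(=O)(=O)NC`) gives 0.2 h. Compound 3 (`CNS(=O)(=O)c1cc(C(=O)O)ccc1NCCCCCCCC(F)(F)F`) gives > 1 h, which is a limit of the assay and not a number.

The next structure, compound 4 (`O=C(O)c1ccc(NCCCCCCCC(F)(F)F)c(S(=O)(=O)NC2CCCC2)c1`), carries cyclopentyl in place of methyl on a sulfonamide nitrogen. Within the data shown here, no measured step touches that place, as all three lie on the saturated chain. Ethyl in place of hydrogen gave a 2.4-fold lower number from compound 1 to compound 2 (0.38 log units; beyond the scatter), 2,2,2-trifluoroethyl in place of hydrogen gave an at least 2.0-fold higher number from compound 1 to compound 3 (0.31 log units; beyond the scatter), and trifluoromethyl in place of methyl gave an at least 5.0-fold higher number from compound 2 to compound 3 (0.69 log units; beyond the scatter). These steps show that this assay responds to changes in this series, but they are only a loose guide to a change elsewhere in the molecule. The closest analogy is compound 2, the only case that adds carbon without fluorine, with a 2.4-fold lower number from compound 1 to compound 2 (0.38 log units; beyond the scatter). On that basis, a modest fall is expected, although a change no larger than the scatter remains possible. The estimated change is an at least 1.4-fold lower number from compound 3 to compound 4 (0.15 log units; that floor lies within the scatter). For compound 4 the expected half-life is 0.7 h, with an estimated range from 0.25 h to 1.8 h.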

Compound 4, half-life in the Mus musculus assay: > 1 h
Compound 4 ended at the assay's limit; the forecaster's own chance of this, stated with the estimate: 25%; middle value at least 1.4-fold (0.15 log units) away from the limit.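

In the Mus musculus assay compound 3 gives > 1 h which is a limit of the assay and not a number. In the Mus musculus assay compound 4 gives > 1 h which is also a limit of the assay and not a number. In the Mus musculus assay the step from compound 3 to compound 4 cannot be read, because both compounds sit at the same limit of the assay and neither gives a number: the limit of > 1 h in the Mus musculus assay, at which 2 of the 4 values shown sit.

The compounds shown leave open how long compound 3 and compound 4 last past that limit, and so whether cyclopentyl in place of methyl on a sulfonamide nitrogen shifts the half-life at all.

In a physicochemical assay for solubility, in phosphate buffer, measured as kinetic solubility, at pH 7.4, tested at 250 uM (on this read-out lower numbers stand for lower solubility and higher numbers for higher solubility), compound 3 gives 242000 nM as its measured value, and compound 4 gives 223000 nM as its measured value. In the physicochemical assay the same change gives a 1.1-fold lower number from compound 3 to compound 4 (0.04 log units; within the scatter) and so these two values lie within the scatter of each other.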